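The compounds below may be only part of what the source reports. "The series", "measured", "known", "first", "only" and "open" are said of these compounds alone.

Compound 1 `C[C@@H](O[C@H]1CN2C(=O)C=C(c3ccc(NS(C)(=O)=O)cc3)CC2[C@@H]1c1ccc(F)cc1)c1cc(C(F)(F)F)cc(C(F)(F)F)c1` gives 1 nM in an assay on CHO cells for displacement of a labelled ligand from Substance-P receptor (Homo sapiens); on this read-out higher numbers stand for weaker inhibition and lower numbers for stronger inhibition.
Compound 2 `Cc1cc(C2=CC(=O)N3C[C@H](O[C@H](C)c4cc(C(F)(F)F)cc(C(F)(F)F)c4)[C@@H](c4ccc(F)cc4)C3C2)ccn1` gives 0.51 nM in this assay.
Compound 3 `C[C@@H](O[C@H]1CN2C(=O)C=C(c3cc[nH]c(=O)c3)CC2[C@@H]1c1ccc(F)cc1)c1cc(C(F)(F)F)cc(C(F)(F)F)c1` gives 0.27 nM in this assay.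

Compound 2 sits between the other two, separated from each by a gap within the scatter: a 2.0-fold lower number from compound 1 to compound 2 (0.29 log units; within the scatter) and a 1.9-fold lower number from compound 2 to compound 3 (0.28 log units; within the scatter). Within the data shown here, the only step beyond the scatter, a 3.7-fold lower number from compound 1 to compound 3 (0.57 log units; beyond the scatter), is modest. Compound 4 `C[C@@H](O[C@H]1CN2C(=O)C=C(c3cnn(Cc4ccccc4)c3)CC2[C@@H]1c1ccc(F)cc1)c1cc(C(F)(F)F)cc(C(F)(F)F)c1` differs from compound 2 in one place: 1-benzyl-1H-pyrazol-4-yl in place of 2-methylpyridin-4-yl on a double-bonded ring carbon. Among the measured compounds shown here, no measured step exchanges this particular pair of groups, so only the general picture applies: three different groups on this double-bonded ring carbon all gave values in a narrow band, with steps between them small or modest. For compound 4 a step of at most that size is expected in this assay, in either direction, as a 2.0-fold higher number from compound 2 to compound 4 (0.29 log units; within the scatter). Compound 4 is therefore estimated at 1 nM, with a range from 0.3 nM to 4 nM.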

Compound 4, half-maximal inhibitory concentration: 1.9 nM
For compound 4 the middle estimate is 1.9-fold (0.28 log units) below the measured one, within the range that was stated.
By their numbers in this assay, from the lowest: compounds 3, 2, 1 and 4 (each within the scatter of the next, the first and the last beyond it).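

In this assay, among these compounds, the 1-benzyl-1H-pyrazol-4-yl group brings the first step on this double-bonded ring carbon that moves to a higher number: a 3.7-fold higher number from compound 2 to compound 4 (0.57 log units; beyond the scatter) and a 7.0-fold higher number from compound 3 to compound 4 (0.85 log units; beyond the scatter) lie beyond the scatter while a 1.9-fold higher number from compound 1 to compound 4 (0.28 log units; within the scatter) stays within it. A group with two aromatic rings is therefore compatible with a value in the range of compound 1, though the band of values widens. No evidence at hand explains these differences. The compounds shown leave open whether the steps follow from the five-membered aromatic ring or from the benzyl group, which a methyl group in place of benzyl would separate. From the compounds shown here alone, how an amine or a carboxylic acid on this carbon would read also remains open.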